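Amide aryl swap at the amide carbonyl in a quinolinone series

The compounds below may be only part of what the source reports. "The series", "measured", "known", "first", "only" and "open" are said of these compounds alone.

Measured so far:
Compound 1, `CC(C)=CCC/C(C)=C/CC1Cc2c(OCCCNS(=O)(=O)c3ccc(Br)cc3)cc(=O)n(CCCO)c2CC1(C)C`, gives 0% in a functional assay on PANC-1 cells (Homo sapiens) for inhibition, read by MTT assay, with a stated time of 24 h, tested at 10 uM; on this read-out higher numbers stand for more inhibition at the one concentration tested (going by the name of the read-out) and lower numbers for less inhibition.
Compound 2, `CC(C)=CCC/C(C)=C/CC1Cc2c(OCCCNC(=O)c3cccs3)cc(=O)n(CCCO)c2CC1(C)C`, gives 11.5% in this assay.

Compound 2 stands highest of the two numbers measured, and the change from compound 1 to compound 2 gives a number 11.5 percentage points higher from compound 1 to compound 2 (beyond the scatter), a modest step that rests on exchanging the group on the amine nitrogen. Compound 3, `CC(C)=CCC/C(C)=C/CC1Cc2c(OCCCNC(=O)c3ccc([N+](=O)[O-])cc3)cc(=O)n(CCCO)c2CC1(C)C`, differs from compound 2 by 4-nitrophenyl in place of thiophen-2-yl on a carbonyl carbon. Among the compounds with values here, no measured step in this set changes the group on the carbonyl carbon; the one step known concerns a different place, so it offers no direct guide to the size or direction of this change. In this assay compound 3 is therefore expected to give a step of a number 0.5 percentage points higher from compound 2 to compound 3 (within the scatter), within the scatter. The estimate for compound 3 is 12%, with a range from 0% to 30%.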

Compound 3, a percentage reported as inhibition, at one concentration (the size of the read-out at that concentration, not a potency): 6.5%
The estimate for compound 3 lay 5.5 percentage points above the measured number; measured number inside the range.
By their numbers in this assay, from the lowest: compounds 1, 3 and 2 (each within the scatter of the next, the first and the last beyond it).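

In this assay the exchange of thiophen-2-yl for 4-nitrophenyl on the carbonyl carbon gives a number 5 percentage points lower from compound 2 to compound 3 (within the scatter), so these two rings are not told apart at this position. Set against the (4-bromophenyl)sulfonyl group on the amine nitrogen, the (4-nitrophenyl)carbonyl group gives a number 6.5 percentage points higher from compound 1 to compound 3 (within the scatter), so the gap beyond the scatter seen with the (thiophen-2-yl)carbonyl group does not carry over to this second amide. Nothing in hand explains either step.

From the compounds shown here alone, it stays open whether any group on this carbonyl carbon can give a clear rise in inhibition at the one concentration tested. A plain alkyl chain, or a phenyl ring bearing an amine or a carboxylic acid in place of the nitro group, could show whether this position responds at all.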